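The compounds below may be only part of what the source reports. "The series", "measured", "known", "first", "only" and "open" are said of these compounds alone.

Going by the values given here, compound 2 `Nc1nc(O)c2c(n1)n(C1OC(CO)[C@@H](O)[C@H]1O)c(=O)n2Cc1ccc([N+](=O)[O-])cc1` stands at the top of the two numbers measured so far: in a functional assay on the whole organism (B cells) with Mus musculus as the target (a lower number here means a smaller maximal response, a higher number a larger maximal response), compound 2 reaches 147%. Among the compounds with values here, compound 1 `CCn1c(=O)n(C2OC(CO)[C@@H](O)[C@H]2O)c2nc(N)nc(O)c21` is the only other measured compound, and in this assay compound 1 gives 82%. Within the data shown here, the one measured step, a number 65 percentage points higher from compound 1 to compound 2 (beyond the scatter), is therefore the whole of the evidence.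

Compound 3 `NCC(O)Cn1c(=O)n(C2OC(CO)[C@@H](O)[C@H]2O)c2nc(N)nc(O)c21` differs from compound 2 in one place: 2-amino-1-hydroxyethyl in place of 4-nitrophenyl on a saturated chain carbon bound to an aromatic nitrogen. The step that bears on this change is a number 65 percentage points higher from compound 1 to compound 2 (beyond the scatter), where a 4-nitrophenyl entering on that saturated chain carbon raised the maximal response by a large margin. In compound 3 the 4-nitrophenyl leaves again, but what enters is the 2-amino-1-hydroxyethyl rather than the methyl of compound 1, so the measured step cannot simply be read backwards. A downward step beyond the scatter is nonetheless expected for compound 3, a number 57 percentage points lower from compound 2 to compound 3 (beyond the scatter), since the group whose arrival brought the large rise is removed. The estimate for compound 3 in this assay is 90%, with a range from 60% to 130%.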

Compound 3, largest response reached (reported as maximal response), in percent of the reference or control that the assay uses: 110%
The estimate for compound 3 lay 20 percentage points below the measured number; the range from low to high includes it.
By their numbers in this assay, from the lowest: compound 1; then compound 3; then compound 2.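

Going by these compounds alone, at the saturated chain carbon bound to an aromatic nitrogen, the 4-nitrophenyl is not the only group that lifts the response in this assay: the 2-amino-1-hydroxyethyl, which has no ring, gives a number 28 percentage points higher from compound 1 to compound 3 (beyond the scatter). That gain does not match the one from the 4-nitrophenyl, since the exchange of groups gives a number 37 percentage points lower from compound 2 to compound 3 (beyond the scatter), so the three groups at this place rank from methyl through 2-amino-1-hydroxyethyl to 4-nitrophenyl, with every step beyond the scatter. No measurement shown here accounts for this order.

The compounds shown do not separate the hydroxyl from the amine of the 3-amino-2-hydroxypropyl, as the two enter together, so a plain propyl chain or a 2-hydroxypropyl chain without the amine would be needed to tell what each contributes. Nor do they show whether the high response of compound 2 belongs to the benzene ring or to its nitro group, a question that an unsubstituted benzyl group at the same place would address.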